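Lengthening the hydroxamic acid chain on compound 2

The source may hold more compounds than are shown below. What is called first, only, known or untested is meant among the compounds shown, and "the series" means these compounds.

Values so far in a functional assay on MCF7 cells (Homo sapiens) for antiproliferative activity, read by MTT assay, with a stated time of 48 h; a lower number here means a stronger inhibitor, a higher number a weaker inhibitor
- compound 1 `COc1cc2ncnc(Nc3cccc(Br)c3)c2cc1OCCCC(=O)NO` gives 68400 nM
- compound 2 `COc1cc2ncnc(Nc3cc(Cl)ccc3Cl)c2cc1OCCCC(=O)NO` gives 44500 nM

Going by the values given here, the only measured step is a 1.5-fold lower number from compound 1 to compound 2 (0.19 log units; within the scatter) and it lies within the scatter, so the two compounds stand level on these numbers. Compound 3 `COc1cc2ncnc(Nc3cc(Cl)ccc3Cl)c2cc1OCCCCC(=O)NO` keeps the 2,5-dichlorophenyl of compound 2 and changes only the chain. The change is (hydroxycarbamoyl)methyl in place of hydroxycarbamoyl on a saturated chain carbon, three bonds along the chain from an oxygen on an aromatic ring and it also reads as 3-(hydroxycarbamoyl)propyl to 4-(hydroxycarbamoyl)butyl. The measured step concerns the group on the nitrogen and not the chain, so it gives no direct guide here. No shift beyond the scatter is therefore expected in this assay and no direction can be favoured. The expected change is a 1.1-fold lower number from compound 2 to compound 3 (0.05 log units; within the scatter) as a working estimate. For compound 3 the estimated value is 40000 nM with an expected range of 14000 nM to 100000 nM for now.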

Compound 3, half-maximal inhibitory concentration: 13700 nM
For compound 3 the middle estimate is 2.9-fold (0.47 log units) above the measured one; the measured number lies below the stated range.
By their numbers in this assay, from the lowest: compound 3; then compounds 2 and 1 (each within the scatter of the next).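

In this assay, the chain proves responsive to length: a 3.2-fold lower number from compound 2 to compound 3 (0.51 log units; beyond the scatter). Going by these compounds alone, the only earlier step, on the group on the nitrogen, lay within the scatter, so this is the first change to move the number beyond it. With the 2,5-dichlorophenyl held fixed, 4-(hydroxycarbamoyl)butyl gives a lower number than 3-(hydroxycarbamoyl)propyl, and no measured evidence here accounts for this difference.

As far as these compounds go, whether a longer chain, such as 5-(hydroxycarbamoyl)pentyl, lowers the number further remains open, as does whether the same lengthening holds with the 3-bromophenyl of compound 1. Also open, from the compounds shown here alone, is how much of the result depends on the hydroxycarbamoyl end itself, which a carboxylic acid in its place would test.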